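Swapping a Cyclohexyl for a Methyl on the Anilide

The source may report more compounds than this note shows. Statements on the series, on what has been measured and on what is new or still open speak of the compounds shown alone.

Compound 1 `Cc1ccccc1NS(=O)(=O)c1ccc(N2CCNC2=O)cc1`: 200 nM
Compound 2 `O=C1NCCN1c1ccc(S(=O)(=O)Nc2ccc(C3CCCCC3)cc2)cc1`: > 1000 nM
Compound 3 `O=C1NCCN1c1ccc(S(=O)(=O)Nc2cccc(Oc3ccccc3)c2)cc1`: 200 nM

These three compounds share one core and were tested in a functional assay on HT-29 cells (Homo sapiens) for antiproliferative activity, read by sulforhodamine B assay, with a stated time of 48 h; on this read-out higher numbers stand for weaker inhibition and lower numbers for stronger inhibition. Compound 1 gives 200 nM and compound 3 gives 200 nM; the two values lie within the scatter of each other. Going by these compounds, compound 2 gives only a limit, > 1000 nM, so it stands at the limit of > 1000 nM in this assay, at which 1 of the 3 values shown sits, and its true value is unknown. Compound 4 `Cc1ccc(NS(=O)(=O)c2ccc(N3CCNC3=O)cc2)cc1` has not yet been measured; it differs from compound 2 by methyl in place of cyclohexyl on an aromatic carbon. Since compound 2 is known only as a limit, the step of an at least 2.5-fold lower number from compound 2 to compound 4 (0.39 log units; beyond the scatter) expected from this change, toward stronger inhibition, is uncertain in size. Compound 4 is expected to give about 400 nM, between 150 nM and 1500 nM.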

Compound 4, half-maximal inhibitory concentration: 480 nM
Beside the measured number, compound 4's estimate is 1.2-fold (0.08 log units) below it; the measured number falls inside the stated range.
By their numbers in this assay, from the lowest: compounds 1 and 3 (each within the scatter of the next); then compound 4. At a limit, above all of these: compound 2.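

Putting methyl in place of cyclohexyl on this aromatic carbon gives a real number instead of a limit, with an at least 2.0-fold lower number from compound 2 to compound 4 (0.31 log units; beyond the scatter). The full size of that step cannot be read, as compound 2 is known only as a limit: the limit of > 1000 nM in this assay, at which 1 of the 4 values shown sits. Where the methyl sits also matters, since 4-methylphenyl in place of 2-methylphenyl on the sulfonamide nitrogen gives a 2.4-fold higher number from compound 1 to compound 4 (0.38 log units; beyond the scatter).

The compounds shown leave open how an ethyl group, an isopropyl group or an amine at this same carbon would compare with methyl and cyclohexyl.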